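Working notes: cytotoxicity limits across three measured compounds

A few compounds are considered here, and "the series" means these few. Any claim that something is new, unique, unknown or untested is made for them only; others in the source may bear on it.

Measured so far, in an ADME assay on HEp-2 cells (Homo sapiens) for cytotoxicity, with a stated time of 4 days; a higher number here means that more compound is tolerated, a lower number that less compound is tolerated:
compound 1, `CN(C)S(=O)(=O)c1cn(Cc2nc3cc(Cl)ccc3n2CCCS(C)(=O)=O)c2ccccc12`: > 100000 nM
compound 2, `CS(=O)(=O)CCCn1c(Cn2cc(S(C)(=O)=O)c3ccncc32)nc2cc(Cl)ccc21`: > 100000 nM
compound 3, `CS(=O)(=O)c1nn(Cc2nc3cc(Cl)ccc3n2CCCCO)c2cnccc12`: > 100000 nM

In this assay compound 1 gives > 100000 nM, which is a limit of the assay and not a number. Compound 2 gives > 100000 nM, likewise a limit. Compound 3 gives > 100000 nM, again a limit, so for compound 3 only a limit is known and no number. The picture is uniform: the limit of > 100000 nM in this assay, at which 3 of the 3 values shown sit. Among the measured compounds shown here, no step between two measured compounds differing in one place exists, so nothing measured tells how a single change moves this read-out.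

Compound 4, `CS(=O)(=O)c1nn(Cc2nc3cc(Cl)ccc3n2CC2COC2)c2cnccc12`, has not been measured. It differs from compound 3 as follows: oxetan-3-yl in place of 3-hydroxypropyl on a saturated chain carbon bound to an aromatic nitrogen.

Because every measured compound sits at the same limit (the limit of > 100000 nM in this assay, at which 3 of the 3 values shown sit), the expectation for compound 4 is a value at that limit as well; the expected step of a number no higher from compound 3 to compound 4 (the limit leaves the size open) is none beyond the scatter. Compound 4 is estimated at 100000 nM, with a range from 50000 nM to 200000 nM, and most likely the assay will again report only a limit.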

Compound 4, half-maximal cytotoxic concentration in the HEp-2 assay: > 100000 nM
Compound 4 gave a limit, no number; the forecaster's own chance of this, stated with the estimate: 85%; the middle value lies on the limit itself.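

In the HEp-2 assay compound 3 gives > 100000 nM, which is a limit and not a number. In the HEp-2 assay compound 4 gives > 100000 nM, also a limit and not a number. Among the compounds shown here, no step between compound 3 and compound 4 can be read from these two limits. The compounds shown leave open whether oxetan-3-yl in place of 3-hydroxypropyl moves this read-out at all, and where any actual value lies. In a physicochemical assay for solubility, read by spectrophotometry, in phosphate buffer, at pH 6.5 (on this read-out lower numbers stand for lower solubility and higher numbers for higher solubility), compound 3 gives 147 ug/mL and compound 4 gives 4 ug/mL, and the step reads a 37-fold lower number from compound 3 to compound 4 (1.57 log units; beyond the scatter).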